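A few compounds are considered here, and "the series" means these few. Any claim that something is new, unique, unknown or untested is made for them only; others in the source may bear on it.

Compound 1 `NC(=O)/C=C/c1ccncc1-c1ccc2ccccc2c1` gives > 10000 nM in a functional assay on KB cells (Homo sapiens) for inhibition, read by sulforhodamine B assay, with a stated time of 72 h (on this read-out lower numbers stand for stronger inhibition of growth and higher numbers for weaker inhibition of growth), which is a limit of the assay and not a number.
Compound 2 `CNC(=O)CCc1ccncc1-c1ccc2ccccc2c1` gives > 10000 nM in this assay, again a limit.
Compound 3 `O=C(/C=C/c1ccncc1-c1ccc2cc[nH]c2c1)N1CCOCC1` gives > 10000 nM in this assay, again a limit.

Among the measured compounds shown here, compound 1 thus stands only at a limit, and the one step between measured compounds, a step that the two limits leave unreadable from compound 1 to compound 2, cannot be read because the limit of > 10000 nM in this assay, at which 3 of the 3 values shown sit, holds both ends. Compound 4 `CN1CCN(C(=O)/C=C/c2ccncc2-c2ccc3ccccc3c2)CC1` differs from compound 1 in one place: 4-methylpiperazin-1-yl in place of amino on a carbonyl carbon. For the measured compounds named here, no measured step bears a readable size on this change, since every value shown sits at the limit of > 10000 nM in this assay, at which 3 of the 3 values shown sit. Compound 4 is therefore expected to remain near the limit as well, with a step that the limit leaves unreadable from compound 1 to compound 4 estimated as no step beyond the scatter. The estimate for compound 4 in this assay is 15000 nM, expected to fall between 4000 nM and 60000 nM.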

Compound 4, concentration for 50% growth inhibition: > 10000 nM
Compound 4 ended at the assay's limit; the forecaster's own chance of this, stated with the estimate: 75%; the middle value lies beyond the limit too.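

No size can be read for the change from compound 1 to compound 4, since both values are limits of the assay: the limit of > 10000 nM in this assay, at which 4 of the 4 values shown sit.

The compounds shown leave open how far any of them lies past that limit, and which change to the shared core would bring a value within it.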